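Moving the Fluorine from Compound 1 to Compound 4

The compounds below may be only part of what the source reports. "The series", "measured", "known", "first", "only" and "open" are said of these compounds alone.

In a functional assay on DLA cells (Mus musculus) for cytotoxicity, read by LDH release, with a stated time of 48 h (a higher number here means a weaker inhibitor, a lower number a stronger inhibitor), compound 1 `Cc1cc(C(=O)c2ccc(F)cc2)ccc1OCC(=O)Nc1nc(-c2ccccc2)cs1` gives 34700 nM. Compound 2 `Cc1cc(C(=O)c2ccccc2)cc(C)c1OCC(=O)Nc1nc(-c2ccccc2)cs1` gives 19900 nM, and these two values lie within the scatter of each other. Compound 3 `COc1ccc(-c2csc(NC(=O)COc3ccc(C(=O)c4ccc(F)cc4)cc3C)n2)cc1` gives 5500 nM, which puts it clearly apart from compound 1: the measured step is a 6.3-fold lower number from compound 1 to compound 3 (0.80 log units; beyond the scatter). That step is methoxy in place of hydrogen on an aromatic carbon.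

Compound 4 `Cc1cc(C(=O)c2ccccc2F)ccc1OCC(=O)Nc1nc(-c2ccccc2)cs1` has the same atoms as compound 1, joined differently: 2-fluorophenyl in place of 4-fluorophenyl on a carbonyl carbon. In words, it carries 2-fluorophenyl in place of 4-fluorophenyl on a carbonyl carbon. For the measured compounds named here, the only measured single-place step, a 6.3-fold lower number from compound 1 to compound 3 (0.80 log units; beyond the scatter), is a different kind of change, so it bears on this one only loosely. Going by the values given here, no measured step moves the fluorine. A shift beyond the scatter in this assay is therefore not expected, and the estimated step is a 1.2-fold lower number from compound 1 to compound 4 (0.06 log units; within the scatter). Compound 4 is expected to give about 30000 nM, with an estimated range of 13000 nM to 70000 nM.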

Compound 4, half-maximal inhibitory concentration: 15600 nM
The estimate for compound 4 lay 1.9-fold (0.28 log units) above the measured number, within the range that was stated.
By their numbers in this assay, from the lowest: compound 3; then compounds 4, 2 and 1 (each within the scatter of the next, the first and the last beyond it).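

Moving the fluorine with no atom gained or lost gives a 2.2-fold lower number from compound 1 to compound 4 (0.35 log units; beyond the scatter) in this assay, so the arrangement on the ring held by the carbonyl carbon matters here, even though the step is modest. For the compounds shown here, until now, the only single-place step was methoxy in place of hydrogen on an aromatic carbon, which said nothing about this ring or about 2-fluorophenyl in place of 4-fluorophenyl. No available evidence explains the shift.

The compounds shown leave open whether 2-fluorophenyl in place of 4-fluorophenyl would give a similar step on the core of compound 3, which carries the methoxy group. They also leave open how an unsubstituted phenyl or a 2-chlorophenyl on the same carbonyl carbon would compare with compound 1 and compound 4.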